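The source may hold more compounds than are shown below. What is called first, only, known or untested is meant among the compounds shown, and "the series" means these compounds.

Of the compounds shown here, three with a shared core have been tested. Compound 1 `CC(C)c1ccc2nc(N)sc2c1` in a functional assay on the whole organism with Rattus norvegicus as the target (a lower number here means that less compound is needed, a higher number that more compound is needed for the effect), reaches only a limit, > 10 mg/kg. Compound 2 `Nc1nc2ccc(C(F)(F)C(F)(F)F)cc2s1` in this assay gives 2.5 mg/kg. Compound 3 `Cn1c(=N)sc2cc(OC(F)(F)F)ccc21` gives 5 mg/kg and stands at the top of the two real numbers, though its gap to compound 2 lies within the scatter, so the two are not separated. The third value, that of compound 1, is a limit, (the limit of > 10 mg/kg in this assay, at which 1 of the 3 values shown sits).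

Compound 4 `CCN(CC)C(=O)Cn1c(=N)sc2cc(OC(F)(F)F)ccc21` has not yet been measured in this assay. Its change from compound 3 is diethylcarbamoyl in place of hydrogen on a saturated chain carbon bound to an aromatic nitrogen. For the measured compounds named here, no measured step of this kind exists among the three compounds. Compound 4 is expected to give 6 mg/kg, between 2 mg/kg and 15 mg/kg. The step from compound 3 is estimated as a 1.2-fold higher number from compound 3 to compound 4 (0.08 log units; within the scatter), a small rise barely beyond the scatter.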

Compound 4, dose for half-maximal effect: 9 mg/kg
Compound 4: the middle estimate sits 1.5-fold (0.18 log units) below what was measured; the range from low to high includes it.
By their numbers in this assay, from the lowest: compounds 2, 3 and 4 (each within the scatter of the next, the first and the last beyond it). At a limit, above all of these: compound 1.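

In this assay, a diethylcarbamoyl group on this saturated chain carbon bound to an aromatic nitrogen, with its 7 heavy atoms, leaves compound 4 within the scatter of compound 3 (a 1.8-fold higher number from compound 3 to compound 4 (0.26 log units; within the scatter)). This position therefore accepts a sizeable amide group without a change that can be told from the scatter. Nothing shown gives a cause for this step.

From the compounds shown here alone, whether a carboxylic acid, an amine or a longer chain on this carbon would behave the same stays open.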